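The source may hold more compounds than are shown below. What is called first, only, known or untested is meant among the compounds shown, and "the series" means these compounds.

Working notes on the series. Compound 1 `O=C(NCc1ccc(F)cc1)c1nc(Br)c2cccnc2c1NCc1ccccc1` and compound 3 `O=C(NCc1ccc(F)cc1)c1nc(Br)c2cccnc2c1N1CCNCC1` carry the shared core of compound 2 `N[C@H]1CC[C@H](Nc2c(C(=O)NCc3ccccn3)nc(Br)c3cccnc23)CC1`. In a functional assay on HCT-116 cells (Homo sapiens) for cytotoxicity, read by MTT assay, with a stated time of 72 h (on this read-out higher numbers stand for weaker inhibition and lower numbers for stronger inhibition), compound 1 gives only a limit, > 20000 nM. Compound 3 in this assay also gives only a limit, > 10000 nM. The step that the two limits leave unreadable from compound 1 to compound 3 cannot be read because the limit of > 20000 nM in this assay, at which 1 of the 3 values shown sits, and the limit of > 10000 nM in this assay, at which 1 of the 3 values shown sits, are both limits rather than numbers. For compound 2 in this assay the result is "not determined" (no result reported), so compound 2 stands nowhere on the numbers shown. Compound 4 `N[C@H]1CC[C@H](Nc2c(C(=O)NCc3ccccc3)nc(Br)c3cccnc23)CC1` differs from compound 2 only by phenyl in place of pyridin-2-yl on a saturated chain carbon bound to an amide-type nitrogen. Within the data shown here, no measured step bears on this change, and with both measured values being limits no step beyond the scatter is expected in this assay. Compound 4 is estimated at 15000 nM, within 3000 nM to 60000 nM.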

Compound 4, half-maximal inhibitory concentration: 7000 nM
Estimate against measurement, compound 4: 2.1-fold (0.33 log units) above; the measured number falls inside the stated range.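

No new step can be read for compound 4, at 7000 nM in this assay: its one-place partner, compound 2, gives "not determined" (no result reported). As far as these compounds go, what phenyl in place of pyridin-2-yl does in this assay stays open.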